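A few compounds are considered here, and "the series" means these few. Any claim that something is new, unique, unknown or untested is made for them only; others in the source may bear on it.

Measured so far:
compound 1, `Fc1ccc(-c2ccc(Cn3nnc4ccccc43)cc2)c(F)c1`, 0.9 mL/min/g
compound 2, `Fc1cc(Cn2nnc3c(Br)cccc32)ccc1Cl`, 0.4 mL/min/g
compound 3, `Brc1cccc2c1nnn2CC1CCCC1`, 7.9 mL/min/g

In an ADME assay on microsomes from liver (Homo sapiens) for metabolic stability, tested at 2.5 uM (on this read-out higher numbers stand for fast clearance and lower numbers for slow clearance), compound 3 stands highest of the three numbers; compound 1 gives 0.9 mL/min/g and compound 2 gives 0.4 mL/min/g, and both gaps to compound 3 lie beyond the scatter. Compound 4, `Brc1cccc2c1nnn2CC1CC1`, is not yet measured in this assay. It differs from compound 3 in one place: cyclopropyl in place of cyclopentyl on a saturated chain carbon bound to an aromatic nitrogen. For the measured compounds named here, no step between measured compounds shows what this change does, so the expectation rests on compound 3 alone. A small step downward, a 1.8-fold lower number from compound 3 to compound 4 (0.24 log units; within the scatter), is expected, though one within the scatter cannot be ruled out. Compound 4 is estimated at 4.5 mL/min/g, with a range from 1.5 mL/min/g to 11 mL/min/g.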

Compound 4, intrinsic clearance in a liver preparation (reported as CLH), per the amount of preparation that the assay uses: 1.3 mL/min/g
Beside the measured number, compound 4's estimate is 3.5-fold (0.54 log units) above it; the measured number lies below the stated range.
By their numbers in this assay, from the lowest: compound 2; then compounds 1 and 4 (each within the scatter of the next); then compound 3.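

In this assay, cyclopropyl in place of cyclopentyl on a saturated chain carbon bound to an aromatic nitrogen gives a 6.1-fold lower number from compound 3 to compound 4 (0.78 log units; beyond the scatter). With the rest of the structure held the same, the group at this place alone moves the clearance number beyond the scatter. No available evidence gives a cause for this step. The compounds shown leave open where a cyclobutyl or cyclohexyl ring at this place would stand relative to compound 3 and compound 4. They also leave open what an open chain such as isopropyl, or an amine, would give there.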